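This account rests on a few compounds, and the source may have more. Where it says the series, first, only, none or still open, it means among the compounds named here.

Measured compounds in a functional assay on HCT-116 cells (Homo sapiens) for antiproliferative activity, read by MTT assay, with a stated time of 72 h; on this read-out lower numbers stand for stronger inhibition and higher numbers for weaker inhibition:
compound 1, `Nc1nc(N)c2cc(CSC(=S)N3CCN(c4ccc(O)cc4)CC3)ccc2n1`, 5980 nM
compound 2, `Cc1ccccc1N1CCN(C(=S)SCc2ccc3nc(N)nc(N)c3c2)CC1`, 11800 nM
compound 3, `Cc1ccc(N2CCN(C(=S)SCc3ccc4nc(N)nc(N)c4c3)CC2)c(C)c1`, 4070 nM

Compound 1 sits second highest of the three numbers; its nearest neighbour is compound 3, and its furthest is compound 2, and both gaps are within the scatter. Among the measured compounds shown here, the only step beyond the scatter is a 2.9-fold lower number from compound 2 to compound 3 (0.46 log units; beyond the scatter), which is methyl in place of hydrogen on an aromatic carbon of the ring on the amine nitrogen.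

The unmeasured compound 4, `CC(=O)c1ccc(N2CCN(C(=S)SCc3ccc4nc(N)nc(N)c4c3)CC2)cc1`, differs from compound 1 by acetyl in place of hydroxy on an aromatic carbon. For the measured compounds named here, the steps that bear on it are those that change the same ring: a 2.0-fold higher number from compound 1 to compound 2 (0.30 log units; within the scatter) and a 1.5-fold lower number from compound 1 to compound 3 (0.17 log units; within the scatter), both within the scatter. Neither of them exchanges the hydroxy for a group with an acceptor and no donor, so the acetyl case is not covered directly. Given that swaps on this ring so far moved the read-out by no more than the scatter, no step beyond the scatter is expected in this assay for compound 4, in either direction, with the range left wide. The estimated value of compound 4 in this assay is 5500 nM, between 2000 nM and 15000 nM, meaning an expected step of a 1.1-fold lower number from compound 1 to compound 4 (0.04 log units; within the scatter).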

Compound 4, half-maximal inhibitory concentration: 8260 nM
Beside the measured number, compound 4's estimate is 1.5-fold (0.18 log units) below it, and the stated range covers the measured number.
By their numbers in this assay, from the lowest: compounds 3, 1, 4 and 2 (each within the scatter of the next, the first and the last beyond it).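

Working notes on the 4-hydroxyphenyl to 4-acetylphenyl change: in this assay the change gives a 1.4-fold higher number from compound 1 to compound 4 (0.14 log units; within the scatter) and so removes the hydrogen-bond donor, keeps a hydrogen-bond acceptor and adds two heavy atoms on this aromatic carbon without a shift beyond the scatter, a case the earlier methyl-bearing rings did not cover. Set against those rings, the 4-acetylphenyl group gives a 1.4-fold lower number from compound 2 to compound 4 (0.15 log units; within the scatter) and a 2.0-fold higher number from compound 3 to compound 4 (0.31 log units; beyond the scatter), so only the second step, a modest one, lies beyond the scatter, and compound 3 is separated from compound 2 and compound 4 but not from compound 1, which keeps the series from splitting into two clean groups. No supporting data bear on why the change leaves the read-out where it is.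

The compounds shown leave open whether a carboxylic acid or a primary amine on this same aromatic carbon, para to the large group, would stay in this range of values. Going by these compounds, it is also open whether a longer acyl chain such as butanoyl in place of acetyl would produce a step beyond the scatter from compound 1 or compound 4.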